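Alkyl substitution on the aryl isoxazole: expectation for compound 4

A few compounds are considered here, and "the series" means these few. Any claim that something is new, unique, unknown or untested is made for them only; others in the source may bear on it.

Measured compounds:
compound 1 `CCCc1cc(-c2cn([C@H]3C[C@H](OC(C)=O)[C@@H](COC(C)=O)O3)c(=O)[nH]c2=O)on1` — 96.9%
compound 2 `CC(=O)OC[C@H]1O[C@@H](n2cc(-c3cc(-c4ccc(C(C)(C)C)cc4)no3)c(=O)[nH]c2=O)C[C@@H]1OC(C)=O` — 112%
compound 3 `CC(=O)OC[C@H]1O[C@@H](n2cc(-c3cc(-c4ccccc4)no3)c(=O)[nH]c2=O)C[C@@H]1OC(C)=O` — 91.4%

In a functional assay on NCI-H23 cells (Homo sapiens) for cytotoxicity, read by sulforhodamine B assay, tested at 10 uM (on this read-out lower numbers stand for less inhibition and higher numbers for more inhibition at the one concentration tested (going by the name of the read-out)), compound 3 stands lowest of the three numbers. Its nearest neighbour is compound 1, a gap that lies within the scatter, as a number 5.5 percentage points lower from compound 1 to compound 3 (within the scatter) shows; its furthest neighbour is compound 2, and there a number 20.6 percentage points lower from compound 2 to compound 3 (beyond the scatter) is beyond the scatter.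

Compound 4 `CCc1ccc(-c2cc(-c3cn([C@H]4C[C@H](OC(C)=O)[C@@H](COC(C)=O)O4)c(=O)[nH]c3=O)on2)cc1` differs from compound 3 by one change: ethyl in place of hydrogen on an aromatic carbon. Among the compounds with values here, the step that bears on this is the one from compound 2 to compound 3, a number 20.6 percentage points lower from compound 2 to compound 3 (beyond the scatter), in which the removal of tert-butyl from the same ring carbon lowered the number by a modest amount; the comparison of compound 1 with compound 2, a number 15.1 percentage points higher from compound 1 to compound 2 (beyond the scatter), points the same way, with the larger aryl group reading higher. Ethyl is a smaller group than tert-butyl, so the return of an alkyl group at this position is expected to bring back only part of that difference.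

For compound 4 the step of a number 9.6 percentage points higher from compound 3 to compound 4 (within the scatter) is therefore expected, a modest rise that may not clear the scatter. The estimate for compound 4 is 101%, with a range from 88% to 114%.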

Compound 4, a percentage reported as inhibition, at one concentration (the size of the read-out at that concentration, not a potency): 92.7%
Beside the measured number, compound 4's estimate is 8.3 percentage points above it, within the range that was stated.
By their numbers in this assay, from the lowest: compounds 3, 4 and 1 (each within the scatter of the next); then compound 2.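

In this assay, ethyl on this ring carbon, para to a large group, does not separate from hydrogen (a number 1.3 percentage points higher from compound 3 to compound 4 (within the scatter)), so adding an alkyl group here does not by itself give a reading distinct from the unsubstituted phenyl. The exchange of tert-butyl for ethyl at the same carbon is the step that clears the scatter (a number 19.3 percentage points lower from compound 2 to compound 4 (beyond the scatter)), so among hydrogen, ethyl and tert-butyl only tert-butyl stands apart, and the high reading of compound 2 does not extend to the smaller alkyl group. The comparison with the propyl compound also stays within the scatter (a number 4.2 percentage points lower from compound 1 to compound 4 (within the scatter)), which leaves compound 1, compound 3 and compound 4 as one group at the single concentration tested, with compound 2 alone above them.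

No measurement available here explains why tert-butyl and ethyl differ at this carbon. Open questions are where along the alkyl groups the reading begins to separate, for example with isopropyl or a longer chain such as butyl, and whether a non-alkyl group on the same carbon, such as an amine or a carboxylic acid, would separate from hydrogen.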